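Sulfonyl Aryl Exchange Set Against Two Assay Limits

The compounds below may be only part of what the source reports. "The series", "measured", "known", "first", "only" and "open" are said of these compounds alone.

Compound 1 `Cc1ccc(S(=O)(=O)Nc2ccc3oc(-c4ccccc4)nc3c2)cc1`: > 63000 nM
Compound 2 `O=S(=O)(Nc1ccc2oc(-c3ccccc3)nc2c1)c1cccs1`: > 63000 nM

Compound 1 `Cc1ccc(S(=O)(=O)Nc2ccc3oc(-c4ccccc4)nc3c2)cc1` was tested in an assay on isolated protein for inhibition of malate dehydrogenase, mitochondrial (Sus scrofa), with stated times of 45 min and 30 min (on this read-out lower numbers stand for stronger inhibition and higher numbers for weaker inhibition), and returned a limit, > 63000 nM, not a number. Compound 2 `O=S(=O)(Nc1ccc2oc(-c3ccccc3)nc2c1)c1cccs1` likewise returned only a limit in this assay, > 63000 nM. Among the compounds with values here, the step between them, a step that the two limits leave unreadable from compound 1 to compound 2, therefore cannot be read, and compound 2 stands at the limit rather than at any measured position; that the limit of > 63000 nM in this assay, at which 2 of the 2 values shown sit, is the only evidence the pair offers.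

Compound 3 `COc1ccc(S(=O)(=O)Nc2ccc3oc(-c4ccccc4)nc3c2)cc1` has not yet been measured. Its change from compound 2 is 4-methoxyphenyl in place of thiophen-2-yl on a sulfonyl sulfur. Within the data shown here, the one measured step that bears on this position is a step that the two limits leave unreadable from compound 1 to compound 2, and it gives no readable size in either direction; both flanking compounds sit at the limit. No step beyond the scatter can be expected from this change, and the most likely outcome is a third limit. The expected step that the limit leaves unreadable from compound 2 to compound 3 is thus none that the assay could resolve. Compound 3 is expected to give about 100000 nM, within a range from 40000 nM to 300000 nM.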

Compound 3, half-maximal inhibitory concentration: > 63000 nM
Compound 3: no number, only a limit; the forecaster's own chance of this, stated with the estimate: 85%; the middle value does not contradict the limit.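

Compound 3 also returned only a limit, > 63000 nM, in this assay, so no step among compound 1, compound 2 and compound 3 can be read: the limit of > 63000 nM in this assay, at which 3 of the 3 values shown sit.

The compounds shown leave open whether any group on the sulfonyl sulfur gives a measurable inhibition in this assay, and how compound 1, compound 2 and compound 3 truly rank.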